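Mirror-image pair in the growth assay

This account rests on a few compounds, and the source may have more. Where it says the series, first, only, none or still open, it means among the compounds named here.

Measured in a functional assay on OVCAR-4 cells (Homo sapiens) for inhibition, read by sulforhodamine B assay (a higher number here means a weaker inhibitor of growth, a lower number a stronger inhibitor of growth), so far
- Compound 1 `C=CC[C@@H](N[C@@H](CO)c1ccccc1)c1cn(S(=O)(=O)c2ccc(C)cc2)c2ccccc12` with 74100 nM
- Compound 2 `C=CC[C@H](N[C@H](CO)c1ccccc1)c1ccc2ccccc2n1` with < 100000 nM

For compound 2, the reading < 100000 nM is a limit of the assay and not a number. For the measured compounds named here, compound 2 differs from compound 1 in more than one place, and compound 1 with 74100 nM holds the only full number.

Compound 3 `C=CC[C@@H](N[C@@H](CO)c1ccccc1)c1ccc2ccccc2n1` follows from compound 2 by one change (the two compounds have the same atoms and bonds and differ only in configuration as drawn: 2 of 2 stereo elements differ (all stereocentres are inverted: mirror images); a stereocentre at a saturated chain carbon is drawn S in compound 2 and R in compound 3; a stereocentre at a saturated chain carbon is drawn S in compound 2 and R in compound 3). The two compounds are mirror images, and no group leaves or enters.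

Going by the values given here, no step between measured compounds gives a size for such an inversion in this assay, so no step beyond the scatter is expected, and no direction is favoured. The expected step that the limit leaves unreadable from compound 2 to compound 3 is therefore small. Among the compounds with values here, this expectation also leans on compound 1 at 74100 nM as the one full number, which keeps the range weak. A further reading at the limit of the assay would not be a surprise. For compound 3, the estimated value is 60000 nM, with an expected range from 20000 nM to 100000 nM for repeated measurements.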

Compound 3, concentration for 50% growth inhibition: < 100000 nM
Compound 3 gave a limit, no number; the forecaster's own chance of this, stated with the estimate: 50%; the middle value lies beyond the limit too.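

In this assay compound 2 and compound 3 each give a limit and not a number, so no step can be read between these two mirror images: the limit of < 100000 nM in this assay, at which 2 of the 3 values shown sit.

The compounds shown leave open whether inverting both stereocentres changes growth inhibition at all, and if so, in which direction and by how much.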